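A Second Methoxy on Compound 2

The source may report more compounds than this note shows. Statements on the series, on what has been measured and on what is new or still open speak of the compounds shown alone.

In a physicochemical assay for lipophilicity, read by LC-MS, in phosphate buffer, measured as octanol-water partition, with a stated time of 2 h, at pH 7.4 (a higher number here means a more lipophilic compound, a lower number a more polar compound), compound 1 `COc1ccccc1C1=NN(c2ccccn2)C(=O)C1` gives 2.56 and compound 2 `COc1ccc(C2=NN(c3ccccn3)C(=O)C2)cc1` gives 2.82 and these two values stand within the scatter of each other. Compound 3 `COc1ccc(C2=NN(c3ccccn3)C(=O)C2)cc1OC` differs from compound 2 by methoxy in place of hydrogen on an aromatic carbon with methoxy in place of hydrogen on an aromatic carbon, ortho to a methoxy group. Among the measured compounds shown here, no measured pair shows this change, and no step beyond the scatter is expected in this assay for it. The estimated change is a number 0.03 log units higher from compound 2 to compound 3 (within the scatter) and it stays within the scatter. Compound 3 is expected at 2.85 with 2.45 to 3.25 as the estimated range.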

Compound 3, distribution coefficient: 2.19
Compound 3: middle estimate off by 0.66 log units, on the high side; measured number below the stated range.
By their numbers in this assay, from the lowest: compound 3; then compounds 1 and 2 (each within the scatter of the next).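

In this assay a methoxy in place of hydrogen on an aromatic carbon, ortho to a methoxy group, gives a number 0.63 log units lower from compound 2 to compound 3 (beyond the scatter). This is the first step beyond the scatter among these compounds, and it shows that this position does not leave the number in place when the group enters. Nothing available accounts for the direction of this step. From the compounds shown here alone, whether an amine or a carboxylic acid at this position would move the number in the same way remains open.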